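The compounds below may be only part of what the source reports. "The series", "measured", "known", "first", "only" and "open" are said of these compounds alone.

Compound 1 `COC(=O)N[C@H](C(=O)N1C[C@@H](C)C[C@H]1c1ncc(-c2ccc(-c3ccc(-c4cc5[nH]c([C@@H]6C[C@H](C)CN6C(=O)[C@@H](NC(=O)OC)C(C)C)nc5s4)cc3)c(F)c2)[nH]1)C(C)C` gives 3100 nM in an ADME assay on HuhET cells (Homo sapiens) for cytotoxicity, read by thymidine incorporation; on this read-out lower numbers stand for higher toxicity in this test and higher numbers for lower toxicity in this test.
Compound 2 `COC(=O)N[C@H](C(=O)N1C[C@@H](C)C[C@H]1c1ncc(-c2ccc(-c3ccc(-c4cc5[nH]c([C@@H]6C[C@H](C)CN6C(=O)[C@@H](NC(=O)OC)C(C)C)nc5s4)cc3)cc2F)[nH]1)C(C)C` gives in this assay only a limit, > 20000 nM.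
Compound 3 `COC(=O)N[C@H](C(=O)N1C[C@@H](C)C[C@H]1c1ncc(-c2ccc(-c3ccc(-c4cc5[nH]c([C@@H]6C[C@H](C)CN6C(=O)[C@@H](NC(=O)OC)C(C)C)nc5s4)cc3)c(C)c2)[nH]1)C(C)C` gives in this assay only a limit, > 20000 nM.

Compound 1 and compound 2 are built from the same atoms joined differently; the difference between the two cores is not broken down here. From compound 1 to compound 3 the change is methyl in place of fluoro on an aromatic carbon, and in this assay it gave an at least 6.4-fold higher number from compound 1 to compound 3 (0.80 log units; beyond the scatter). Compound 4 `COC(=O)N[C@H](C(=O)N1C[C@@H](C)C[C@H]1c1ncc(-c2ccc(-c3ccc(-c4cc5[nH]c([C@@H]6C[C@H](C)CN6C(=O)[C@@H](NC(=O)OC)C(C)C)nc5s4)cc3)cc2C)[nH]1)C(C)C`, not yet measured, differs from compound 2 by methyl in place of fluoro on an aromatic carbon, the same change at the same kind of place. Compound 2 already sits at a limit, and because of the limit of > 20000 nM in this assay, at which 2 of the 3 values shown sit, compound 4 is expected to stay there as well, with a step that the limit leaves unreadable from compound 2 to compound 4; compound 4 is estimated at 30000 nM, between 12000 nM and 100000 nM.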

Compound 4, half-maximal cytotoxic concentration: > 20000 nM
Compound 4: a limit, no number (the forecaster's own chance of this, stated with the estimate: 85%); the middle value is on the limit's open side.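

Compound 2 and compound 4 both give only a limit in this assay, so the step between them cannot be read: the limit of > 20000 nM in this assay, at which 3 of the 4 values shown sit.

The compounds shown leave open whether methyl in place of fluoro changes the true value at this place at all.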